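The source may report more compounds than this note shows. Statements on the series, on what has been measured and on what is new or still open speak of the compounds shown alone.

Of the compounds shown here, three that share one core have been tested in a functional assay on HeLa cells (Homo sapiens) for inhibition, read by CCK-8 assay, with a stated time of 72 h, tested at 8 uM; on this read-out higher numbers stand for more inhibition of growth at the one concentration tested and lower numbers for less inhibition of growth. Compound 1 (`COc1ccc(SCc2ccc(/C=C/C(=O)Nc3ccccc3N)cc2)cc1OC`) gives 21.9%, compound 2 (`Nc1ccccc1NC(=O)/C=C/c1ccc(CSc2ccc(Cl)cc2)cc1`) gives 17.3%, and compound 3 (`CCc1ccc(SCc2ccc(/C=C/C(=O)Nc3ccccc3N)cc2)cc1`) gives 20.9%. Compound 3 therefore cannot be told apart from the other two on these numbers.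

The next compound, compound 4 (`CC(C)(C)c1ccc(SCc2ccc(/C=C/C(=O)Nc3ccccc3N)cc2)cc1`), differs from compound 3 in one place: tert-butyl in place of ethyl on an aromatic carbon. This puts tert-butyl in place of ethyl on an aromatic carbon, para to a large group.

The measured steps that bear on this change are those that alter the same aryl group on the sulfur. They are a number 4.6 percentage points lower from compound 1 to compound 2 (within the scatter), a number 1 percentage points lower from compound 1 to compound 3 (within the scatter) and a number 3.6 percentage points higher from compound 2 to compound 3 (within the scatter). The last of these also swaps the ethyl group, here for chloro. None of the three steps stands out from the usual scatter, so no step beyond the scatter, in either direction, is expected in this assay for this change.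

The estimated step is a number 0.1 percentage points higher from compound 3 to compound 4 (within the scatter). The expected value for compound 4 is 21%, with an estimated range from 11% to 32%.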

Compound 4, percent growth inhibition at one concentration: 9.8%
The estimate for compound 4 lay 11.2 percentage points above the measured number; the whole stated range lies above it.
By their numbers in this assay, from the lowest: compounds 4, 2, 3 and 1 (each within the scatter of the next, the first and the last beyond it).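

In this assay the aryl group on the sulfur had shown no step beyond the scatter, but this position does respond to a change: tert-butyl in place of ethyl gives a number 11.1 percentage points lower from compound 3 to compound 4 (beyond the scatter) on an otherwise unchanged compound. The change to 4-(tert-butyl)phenyl from 3,4-dimethoxyphenyl gives a number 12.1 percentage points lower from compound 1 to compound 4 (beyond the scatter) as well, while tert-butyl in place of chloro gives a number 7.5 percentage points lower from compound 2 to compound 4 (within the scatter) and so does not separate these two compounds. No measurement here accounts for the lower number of compound 4.

Still open is whether isopropyl, which is not among these compounds, would read like ethyl or like tert-butyl. An amine or a carboxylic acid at the same place is also untested by the compounds shown, so the reach of this effect remains unknown.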